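Phenyl Replaces a Branched Alkyl on the Shared Core

The source may hold more compounds than are shown below. What is called first, only, known or untested is meant among the compounds shown, and "the series" means these compounds.

Going by the values given here, compound 3 `CCC(C)(CC)Cc1cnc(CCc2ccc(-c3ccccc3C(=O)O)cc2)[nH]1` gives 76 nM in an in vitro functional assay on cells for agonist activity at Bombesin receptor subtype-3 (Homo sapiens), read by luminescence and calcium flux (a higher number here means that more compound is needed for the effect, a lower number that less compound is needed), the lowest of the three numbers so far, though its gap to compound 2 lies within the scatter. Compound 2 `CC(C)CCc1cnc(CCc2ccc(-c3ccccc3C(=O)O)cc2)[nH]1` gives 119 nM, and compound 1 `O=C(O)c1ccccc1-c1ccc(CCc2ncc(Cc3ccccc3Cl)[nH]2)cc1` gives 292 nM. Compound 4 `O=C(O)c1ccccc1-c1ccc(CCc2ncc(Cc3ccccc3)[nH]2)cc1` has not yet been measured; the change is phenyl in place of 1-ethyl-1-methylpropyl on a saturated chain carbon bound to an aromatic carbon. Among the compounds with values here, three measured steps bear on it: a 3.8-fold lower number from compound 1 to compound 3 (0.58 log units; beyond the scatter), a 2.5-fold lower number from compound 1 to compound 2 (0.39 log units; beyond the scatter) and a 1.6-fold lower number from compound 2 to compound 3 (0.19 log units; within the scatter). Because compound 1 carries a 2-chlorophenyl at the same place and gives 292 nM, the phenyl entering in compound 4 is expected to raise the number toward that of compound 1. The expected step is a 3.2-fold higher number from compound 3 to compound 4 (0.50 log units; beyond the scatter). Compound 4 is therefore estimated at 240 nM, with a range from 90 nM to 700 nM.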

Compound 4, half-maximal effective concentration: 205 nM
Compound 4: middle estimate off by 1.2-fold (0.07 log units), on the high side; low and high end bracket the measured number.
By their numbers in this assay, from the lowest: compounds 3, 2, 4 and 1 (each within the scatter of the next, the first and the last beyond it).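

Phenyl in place of the 1-ethyl-1-methylpropyl group gives a real difference (a 2.7-fold higher number from compound 3 to compound 4 (0.43 log units; beyond the scatter)), so this aromatic ring and this branched alkyl group of equal heavy-atom count are not interchangeable here. Against isobutyl the picture is less sharp: the step (a 1.7-fold higher number from compound 2 to compound 4 (0.24 log units; within the scatter)) does not separate the two groups. Removing the chloro from the ring also gives no clear difference (a 1.4-fold lower number from compound 1 to compound 4 (0.15 log units; within the scatter)), and no measurement at hand explains any of these results. As far as these compounds go, how an amine, a methoxy or a carboxylic acid on the phenyl would compare remains open, as does a longer chain in its place.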